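Ring-nitrogen substitution in the nitro analogue: expected outcome

The compounds below may be only part of what the source reports. "The series", "measured", "known", "first", "only" and "open" are said of these compounds alone.

Measured so far in a functional assay on A549 cells (Homo sapiens) for cytotoxicity, read by MTT assay, with a stated time of 72 h; a lower number here means a stronger inhibitor, a higher number a weaker inhibitor:
compound 1 `CNC(=O)c1cc(Oc2ccc(C3=NNC(c4ccc(C#N)cc4)C3)cc2)ccn1` gives 17400 nM
compound 2 `CNC(=O)c1cc(Oc2ccc(C3CC(c4ccc([N+](=O)[O-])cc4)=NN3)cc2)ccn1` gives "not determined" (no result reported)
compound 3 `CNC(=O)c1cc(Oc2ccc(C3=NN(C(N)=S)C(c4ccc(C#N)cc4)C3)cc2)ccn1` reaches only a limit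

Compound 3 in this assay gives the limit > 50000 nM, which is a limit of the assay and not a number. The step of an at least 2.8-fold higher number from compound 1 to compound 3 (0.45 log units; beyond the scatter) follows the change (a group of 3 heavy atoms (1 carbon, 1 nitrogen, 1 sulfur; no ring) in place of a hydrogen atom, on an amine nitrogen in a ring). The difference between the cores of compound 1 and compound 2 is not broken down here. Compound 4 `CNC(=O)c1cc(Oc2ccc(C3CC(c4ccc([N+](=O)[O-])cc4)=NN3C(N)=S)cc2)ccn1` carries the change (a group of 3 heavy atoms (1 carbon, 1 nitrogen, 1 sulfur; no ring) in place of a hydrogen atom, on an amine nitrogen in a ring), the same kind of change as in compound 3, though the place lines differ around the ring: the substituted nitrogen is next to the ring atom that bears a 4-cyanophenyl group in one and next to the ring atom that bears a large group in the other. The weakening in this assay is anchored by the limit of > 50000 nM in this assay, at which 1 of the 3 values shown sits. Compound 4 is accordingly expected near 50000 nM in this assay, estimated between 15000 nM and 150000 nM.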

Compound 4, half-maximal inhibitory concentration: > 50000 nM
Compound 4 was reported as a limit; the forecaster's own chance of this, stated with the estimate: 60%; the middle value lies on the limit itself.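

In this assay compound 4 gives > 50000 nM, a limit of the assay and not a number. Going by these compounds alone, compound 2 has no reported number, so no step between compound 2 and compound 4 can be read. The compounds shown leave open the actual size of any change on substituting the ring nitrogen in the 4-nitrophenyl compounds.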